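A few compounds are considered here, and "the series" means these few. Any claim that something is new, unique, unknown or untested is made for them only; others in the source may bear on it.

Working notes on the series, read in an assay on cells for inhibition of Amine oxidase [flavin-containing] B (Homo sapiens), read by fluorescence and Amplex Red, with a stated time of 15 min; a higher number here means a weaker inhibitor, a lower number a stronger inhibitor.

Of the compounds shown here, three carry numbers so far. Compound 1 `Cc1cccc2cc(-c3ccc(Br)nn3)c(=O)oc12` gives 2640 nM in this assay. Compound 2 `Cc1cccc2cc(-c3ccc(Cl)nn3)c(=O)oc12` gives 22700 nM in this assay, and compound 3 `COc1cccc2cc(-c3ccc(Cl)nn3)c(=O)oc12` gives 30100 nM in this assay. Compound 2 stands with the second highest number of the three: the gap to compound 3 is within the scatter, while the other gap is a modest step beyond the scatter, an 8.6-fold higher number from compound 1 to compound 2 (0.93 log units; beyond the scatter). The other measured step, a 1.3-fold higher number from compound 2 to compound 3 (0.12 log units; within the scatter), moves methoxy in for methyl on the shared core and stays within the scatter.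

Compound 4 `COc1ccc(-c2cc3cccc(C)c3oc2=O)nn1` differs from compound 2 by methoxy in place of chloro on an aromatic carbon. Among the measured compounds shown here, no measured step exchanges a halogen for methoxy on the six-membered aromatic ring with 2 nitrogen; the only step on that ring is the bromo-to-chloro change from compound 1 to compound 2, and the only methoxy step sits on the shared core of compound 3. Two weak pointers, neither a direct match, so the expectation for compound 4 is a small step, if any, in this assay, estimated as a 1.3-fold higher number from compound 2 to compound 4 (0.12 log units; within the scatter) toward a higher number. Compound 4 is therefore expected to give 30000 nM in this assay, within 9000 nM to 100000 nM.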

Compound 4, half-maximal inhibitory concentration: 5350 nM
The estimate for compound 4 lay 5.6-fold (0.75 log units) above the measured number; the whole stated range lies above it.
By their numbers in this assay, from the lowest: compound 1; then compound 4; then compounds 2 and 3 (each within the scatter of the next).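

In this assay, the place on the six-membered aromatic ring with 2 nitrogen now responds to a change other than one halogen for another: methoxy in place of chloro gives a 4.2-fold lower number from compound 2 to compound 4 (0.63 log units; beyond the scatter). Methoxy does not fully match bromo at this place, with a 2.0-fold higher number from compound 1 to compound 4 (0.31 log units; beyond the scatter), so with the rest of the molecule held constant the numbers run from bromo, the lowest, through methoxy to chloro, the highest, and the three compounds show this single ranking rather than a trend. No supporting measurement is available to account for this ranking.

The compounds shown leave open how other groups would read at this place, such as an amine, a longer chain like ethoxy, or plain hydrogen, any of which would show whether bromo and methoxy are isolated cases. They also leave open whether methoxy at this place gives a similar step on the core of compound 3, which carries methoxy in place of methyl.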